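Swapping a Halogen on the Far Ring of Compound 3

The source may report more compounds than this note shows. Statements on the series, on what has been measured and on what is new or still open speak of the compounds shown alone.

Compound 3 `O=c1cc(-n2cc(COc3ccc(Br)cc3)nn2)c2cc(Br)ccc2o1` has the highest number of the three compounds measured in a functional assay on A549 cells (Homo sapiens) for antiproliferative activity, read by MTT assay, with a stated time of 48 h (a lower number here means a stronger inhibitor, a higher number a weaker inhibitor), with compound 3 giving 24500 nM. Compound 1 `O=c1cc(-n2cc(COc3ccccc3Br)nn2)c2cc(Br)ccc2o1` gives 8430 nM and compound 2 `O=c1cc(-n2cc(COc3ccccc3O)nn2)c2cc(Br)ccc2o1` gives 7940 nM; the steps of a 2.9-fold higher number from compound 1 to compound 3 (0.46 log units; beyond the scatter) and a 3.1-fold higher number from compound 2 to compound 3 (0.49 log units; beyond the scatter) both lie beyond the scatter. Compound 4 `O=c1cc(-n2cc(COc3ccc(F)cc3)nn2)c2cc(Br)ccc2o1` differs from compound 3 by fluoro in place of bromo on an aromatic carbon, on an aromatic carbon of a six-membered aromatic ring of carbon only, para to a large group. Within the data shown here, the one measured exchange of a group on an aromatic carbon, a 1.1-fold lower number from compound 1 to compound 2 (0.03 log units; within the scatter), stays within the scatter, though it concerns another position. Among the measured compounds shown here, no measured step changes a halogen at this position. For compound 4 a small step, a 1.2-fold lower number from compound 3 to compound 4 (0.09 log units; within the scatter), is therefore expected. Compound 4 is estimated at 20000 nM, with a range from 8000 nM to 50000 nM.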

Compound 4, half-maximal inhibitory concentration: 850 nM
Compound 4: the middle estimate sits 24-fold (1.37 log units) above what was measured, outside the stated range (below it).
By their numbers in this assay, from the lowest: compound 4; then compounds 2 and 1 (each within the scatter of the next); then compound 3.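

In this assay, among these compounds, fluoro in place of bromo at this place on the aromatic ring brings a 29-fold lower number from compound 3 to compound 4 (1.46 log units; beyond the scatter) and exceeds every earlier step, so this halogen matters far more than the earlier compounds could show. The 4-fluorophenyl group also outdoes both groups with a substituent at the 2-position, as a 9.3-fold lower number from compound 2 to compound 4 (0.97 log units; beyond the scatter) and a 9.9-fold lower number from compound 1 to compound 4 (1.00 log units; beyond the scatter) show. Nothing available explains this gain.

The compounds shown leave open how chloro or an amine would compare at this place, and whether a 2-fluorophenyl group would give a similar gain.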